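Swapping the Thiazole Amide for a Methylpyridine Amide

The source may hold more compounds than are shown below. What is called first, only, known or untested is meant among the compounds shown, and "the series" means these compounds.

compound 1, `C[C@@H](NC(=O)C1(NC(=O)c2cncs2)CC1)c1ccc(-n2nc(Cl)c3ccccc32)cc1F`: 1.1 mL/min/kg
compound 2, `C[C@@H](NC(=O)C1(NC(=O)c2ccc(Br)nc2)CC1)c1ccc(-n2nc(Cl)c3ccccc32)cc1F`: 2.6 mL/min/kg

In an in vivo ADME assay on the whole organism (strain Mongrel) for pharmacokinetics, with Canis familiaris (Canis lupus familiaris) as the target (a lower number here means slower removal, a higher number faster removal of the compound), compound 1 gives 1.1 mL/min/kg, the lowest of the two numbers, while compound 2 gives 2.6 mL/min/kg. Compound 3 `Cc1cncc(C(=O)NC2(C(=O)N[C@H](C)c3ccc(-n4nc(Cl)c5ccccc54)cc3F)CC2)c1` has not yet been measured; it differs from compound 1 by 5-methylpyridin-3-yl in place of 1,3-thiazol-5-yl on a carbonyl carbon. Among the compounds with values here, the only measured step that bears on this is a 2.4-fold higher number from compound 1 to compound 2 (0.37 log units; beyond the scatter), where another six-membered aromatic ring replaced the same five-membered aromatic ring on the same carbonyl carbon. A similarly modest rise is therefore expected, so compound 3 is estimated at 2 mL/min/kg, within a range from 1 mL/min/kg to 4 mL/min/kg, which means an expected step of a 1.8-fold higher number from compound 1 to compound 3 (0.26 log units; within the scatter).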

Compound 3, clearance: 4.3 mL/min/kg
For compound 3 the middle estimate is 2.2-fold (0.33 log units) below the measured one, and the stated range ends below it.
By their numbers in this assay, from the lowest: compound 1; then compounds 2 and 3 (each within the scatter of the next).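

In this assay, a second six-membered ring on this carbonyl carbon also stands clear of the 1,3-thiazol-5-yl, with a 3.9-fold higher number from compound 1 to compound 3 (0.59 log units; beyond the scatter). The two pyridine groups are not separated, with a 1.7-fold higher number from compound 2 to compound 3 (0.22 log units; within the scatter), so 6-bromopyridin-3-yl and 5-methylpyridin-3-yl read the same here. Nothing available explains why the thiazole amide gives the lowest number. Still open, as far as these compounds go, is whether a pyridin-3-yl ring with no added group, or a plain phenyl ring, would behave like these pyridines, and whether a methyl group on the thiazole would keep the low number of compound 1.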